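This account rests on a few compounds, and the source may have more. Where it says the series, first, only, none or still open, it means among the compounds named here.

Compound 2 `NS(=O)(=O)c1ccc(NC(=S)Nc2ccc3ncnc(Nc4ccc(Cl)c(C(F)(F)F)c4)c3c2)cc1` gives 18200 nM in a functional assay on A-431 cells (Homo sapiens) for antiproliferative activity, read by MTT assay, with a stated time of 72 h (a higher number here means a weaker inhibitor, a lower number a stronger inhibitor), one of two numbers that lie within the scatter of each other; compound 1 `NS(=O)(=O)c1ccc(NC(=S)Nc2ccc3ncnc(Nc4cccc(C(F)(F)F)c4)c3c2)cc1` gives 21700 nM. Compound 3 `NS(=O)(=O)c1ccc(NC(=S)Nc2ccc3ncnc(Nc4ccc(C(F)(F)F)cc4)c3c2)cc1` differs from compound 2 by 4-(trifluoromethyl)phenyl in place of 4-chloro-3-(trifluoromethyl)phenyl on a nitrogen on an aromatic ring. Within the data shown here, the only measured step that bears on this, a 1.2-fold lower number from compound 1 to compound 2 (0.08 log units; within the scatter), concerned the chloro alone and stayed within the scatter; no measured pair shows the trifluoromethyl in a different place on that ring. The expected step of a 1.1-fold higher number from compound 2 to compound 3 (0.04 log units; within the scatter) is therefore small, with no direction beyond the scatter. Compound 3 is estimated at 20000 nM, between 8000 nM and 50000 nM.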

Compound 3, half-maximal inhibitory concentration: 18000 nM
Compound 3: middle estimate off by 1.1-fold (0.05 log units), on the high side; the measured number falls inside the stated range.
By their numbers in this assay, from the lowest: compounds 3, 2 and 1 (each within the scatter of the next).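

In this assay, the change from 4-chloro-3-(trifluoromethyl)phenyl to 4-(trifluoromethyl)phenyl on this nitrogen gives a 1.0-fold lower number from compound 2 to compound 3 (0.00 log units; within the scatter), and the change from 3-(trifluoromethyl)phenyl to 4-(trifluoromethyl)phenyl gives a 1.2-fold lower number from compound 1 to compound 3 (0.08 log units; within the scatter). Among these compounds, the place of the trifluoromethyl on this ring, now compared directly for the first time, therefore makes no readable difference, and the three groups cannot be told apart here. No measurement at hand offers an explanation for this result. Still open, on these data alone, is whether a quite different group on this ring, such as an amine or a carboxylic acid, would move the number beyond the scatter.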